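This account rests on a few compounds, and the source may have more. Where it says the series, first, only, none or still open, it means among the compounds named here.

Compound 1 `O=C(Nc1cccc(-c2ccccc2C(F)(F)F)c1)C(Cl)Cl`: 35900 nM
Compound 2 `O=C(Nc1cccc(-c2cccc(Cl)c2)c1)C(Cl)Cl`: > 50000 nM (a limit of the assay, not a number)

For the measured compounds named here, in a functional assay on KB 3-1 cells (Homo sapiens) for cytotoxicity, read by MTT assay, with a stated time of 68 h (on this read-out lower numbers stand for stronger inhibition and higher numbers for weaker inhibition), compound 1 gives 35900 nM, the only actual number so far. Compound 2 stands at the limit of > 50000 nM in this assay, at which 1 of the 2 values shown sits. Its entry is a limit only.

The next compound is compound 3 `O=C(Nc1cccc(-c2ccccc2)c1)C(Cl)Cl`, which differs from compound 2 at a single place: hydrogen in place of chloro on an aromatic carbon. In words, this is hydrogen in place of chloro on an aromatic carbon, meta to a large group.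

Going by the values given here, no step between measured compounds shows what this change does in this assay, so any expectation rests on thin ground. Among the compounds with values here, the one number available is that of compound 1 at 35900 nM, and compound 3 is expected to fall in the same upper part of the scale. The expected change is small and not clearly beyond the usual scatter, at most slightly towards stronger inhibition: an estimated at least 1.1-fold lower number from compound 2 to compound 3 (0.07 log units; that floor lies within the scatter). A report as a limit again remains quite possible. Compound 3 is expected at 42000 nM, with an estimated range from 22000 nM to 60000 nM.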

Compound 3, half-maximal inhibitory concentration: 46800 nM
Compound 3: middle estimate off by 1.1-fold (0.05 log units), on the low side; the measured number falls inside the stated range.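

Hydrogen in place of trifluoromethyl gives a 1.3-fold higher number from compound 1 to compound 3 (0.12 log units; within the scatter), so in this assay compound 3 shows that a number of this order does not depend on the trifluoromethyl group of compound 1. Hydrogen in place of chloro gives an at least 1.0-fold lower number from compound 2 to compound 3 (0.02 log units; that floor lies within the scatter), so this step shows no change that can be told from the usual scatter, and the chloro group meta to a large group cannot be credited with any clear effect on the read-out. Compound 2 is reported only as a limit, not as a number: the limit of > 50000 nM in this assay, at which 1 of the 3 values shown sits.

The two numbers shown lie within the scatter of each other and in the upper part of the scale, so neither chloro nor trifluoromethyl marks out a substituent that moves the read-out clearly in either direction, and the true size of the step from the chloro compound stays unknown. Going by these compounds, whether an amine, a carboxylic acid or a methoxy group on this aromatic ring would bring the number clearly lower, or push it to a limit again, stays open.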